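The source may report more compounds than this note shows. Statements on the series, on what has been measured and on what is new or still open speak of the compounds shown alone.

Of the compounds shown here, three sharing one core have been measured in an ADME assay on Vero cells (Chlorocebus sabaeus) for cytotoxicity, read by MTT assay, with a stated time of 72 h; a higher number here means that more compound is tolerated, a lower number that less compound is tolerated. Compound 1 `N/C(=N/NC(CC(=O)c1ccc(-n2ccnc2)cc1)c1ccc(Cl)cc1Cl)c1ccccn1` gives 27800 nM. Compound 2 `N/C(=N/NC(CC(=O)c1ccc(-n2ccnc2)cc1)c1ccc(Br)cc1)c1ccccn1` gives 298000 nM. Compound 3 `N/C(=N/NC(CC(=O)c1ccc(-n2ccnc2)cc1)c1ccccc1[N+](=O)[O-])c1ccccn1` gives 48000 nM. Among these three numbers compound 2 stands highest: its nearest neighbour is compound 3, with a 6.2-fold lower number from compound 2 to compound 3 (0.79 log units; beyond the scatter), and the widest gap is an 11-fold higher number from compound 1 to compound 2 (1.03 log units; beyond the scatter). Compound 4 `N/C(=N/NC(CC(=O)c1ccc(-n2ccnc2)cc1)c1ccccc1F)c1ccccn1` has not yet been measured. It differs from compound 2 in one place: 2-fluorophenyl in place of 4-bromophenyl on a saturated chain carbon bound to an amine nitrogen and a saturated chain carbon. Among the measured compounds shown here, two measured steps bear on this change. In each of them the 4-bromophenyl group went with the highest number, and every other group on that saturated chain carbon gave a lower one, as in an 11-fold higher number from compound 1 to compound 2 (1.03 log units; beyond the scatter) and a 6.2-fold lower number from compound 2 to compound 3 (0.79 log units; beyond the scatter); between the two lower compounds the difference is a 1.7-fold higher number from compound 1 to compound 3 (0.24 log units; within the scatter). The 2-fluorophenyl group has not appeared in this set, so the size of its effect is uncertain. For compound 4 a lower number is expected, a 5.0-fold lower number from compound 2 to compound 4 (0.70 log units; beyond the scatter). Compound 4 is therefore estimated at 60000 nM, with a range from 20000 nM to 200000 nM.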

Compound 4, half-maximal cytotoxic concentration: 62100 nM
Estimate against measurement, compound 4: 1.0-fold (0.01 log units) below, and the stated range covers the measured number.
By their numbers in this assay, from the lowest: compounds 1, 3 and 4 (each within the scatter of the next, the first and the last beyond it); then compound 2.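

In this assay there is a 4.8-fold lower number from compound 2 to compound 4 (0.68 log units; beyond the scatter) on replacing 4-bromophenyl with 2-fluorophenyl, so a third group on the saturated chain carbon falls short of the 4-bromophenyl group of compound 2. The 2-fluorophenyl and 2-nitrophenyl groups cannot be told apart, given a 1.3-fold higher number from compound 3 to compound 4 (0.11 log units; within the scatter) within the scatter, whereas a 2.2-fold higher number from compound 1 to compound 4 (0.35 log units; beyond the scatter) separates 2-fluorophenyl from 2,4-dichlorophenyl by a modest margin. Nothing measured here offers a reason for these differences.

Compound 2 and compound 4 differ in both the halogen and its place on the ring, so the compounds shown do not say which of the two matters. A 4-fluorophenyl or 2-bromophenyl group would separate them, and an unsubstituted phenyl group would show what the ring gives alone.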